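Swapping the amine tail of compound 1 for a benzyl(methyl)amino group

The source may hold more compounds than are shown below. What is called first, only, known or untested is meant among the compounds shown, and "the series" means these compounds.

Compound 1 `CCN(CC)CCCOc1ccc2cc(NC(=O)c3ccc(O)c(CC=C(C)C)c3)c(=O)oc2c1C` has the higher of the two numbers recorded so far; in a functional assay on MCF7 cells (Homo sapiens) for antiproliferative activity (on this read-out higher numbers stand for weaker inhibition and lower numbers for stronger inhibition), compound 1 gives 6390 nM. Compound 2 `CC(C)=CCc1cc(C(=O)Nc2cc3ccc(OCCCNC4CCCCC4)c(C)c3oc2=O)ccc1O` differs from it only at the amine on the chain, and in this assay compound 2 gives 1070 nM, a step of a 6.0-fold lower number from compound 1 to compound 2 (0.78 log units; beyond the scatter).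

Compound 3 `CC(C)=CCc1cc(C(=O)Nc2cc3ccc(OCCCN(C)Cc4ccccc4)c(C)c3oc2=O)ccc1O` is the next compound to be measured. It differs from compound 1 in one place: benzyl(methyl)amino in place of diethylamino on a saturated chain carbon, three bonds along the chain from an oxygen on an aromatic ring. Going by the values given here, the only measured step that bears on this change is the one from compound 1 to compound 2, where a larger ring-bearing amine replaced diethylamino at the same place and the number fell by a 6.0-fold lower number from compound 1 to compound 2 (0.78 log units; beyond the scatter). Since benzyl(methyl)amino is likewise larger than diethylamino and carries a ring, a step in the same direction, though perhaps smaller, is expected, of about a 3.2-fold lower number from compound 1 to compound 3 (0.50 log units; beyond the scatter). Compound 3 is therefore estimated to give 2000 nM in this assay, with a range from 700 nM to 5500 nM.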

Compound 3, half-maximal inhibitory concentration: 11500 nM
Compound 3: middle estimate off by 5.8-fold (0.76 log units), on the low side, outside the stated range (above it).
By their numbers in this assay, from the lowest: compound 2; then compounds 1 and 3 (each within the scatter of the next).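

In this assay, the step of a 1.8-fold higher number from compound 1 to compound 3 (0.26 log units; within the scatter) shows that benzyl(methyl)amino and diethylamino cannot be told apart at this place on the chain, so a larger amine carrying a ring does not by itself bring the gain seen with compound 2. The step of an 11-fold higher number from compound 2 to compound 3 (1.03 log units; beyond the scatter) is large and separates two ring-bearing amines, which shows that the result depends on which ring-bearing amine sits at the end of the 3-carbon chain, and that cyclohexylamino stands apart from both other groups. No measurement shown here explains why these amines differ in this way.

Cyclohexylamino and benzyl(methyl)amino differ both in the ring and in the methyl on the nitrogen, so these compounds leave open which of the two features goes with the large step. A benzylamino or cyclohexyl(methyl)amino group at the same place would change only one of these features, and a piperidine would show how an amine fares when its nitrogen is itself part of the ring.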